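This account rests on a few compounds, and the source may have more. Where it says the series, first, only, none or still open, it means among the compounds named here.

Compound 1 `COc1cccc(CNC(=O)c2nc(Br)c3cccnc3c2N[C@H]2CC[C@H](N)CC2)c1` is the starting point. Among the compounds with values here, in a functional assay on SK-BR-3 cells (Homo sapiens) for cytotoxicity, read by MTT assay, with a stated time of 72 h (on this read-out higher numbers stand for weaker inhibition and lower numbers for stronger inhibition), compound 1 gives 6000 nM, the second highest of the three numbers known; compound 3 `COc1ccc(CNC(=O)c2nc(Br)c3cccnc3c2N[C@H]2CC[C@H](N)CC2)cc1` gives 5000 nM and compound 2 `N[C@H]1CC[C@H](Nc2c(C(=O)NCc3ccco3)nc(Br)c3cccnc23)CC1` gives 10000 nM. Within the data shown here, the only measured steps change the ring on the saturated chain carbon bound to the amide-type nitrogen: a 1.7-fold higher number from compound 1 to compound 2 (0.22 log units; within the scatter), a 1.2-fold lower number from compound 1 to compound 3 (0.08 log units; within the scatter) and a 2.0-fold lower number from compound 2 to compound 3 (0.30 log units; within the scatter), all within the scatter. Compound 4 `N[C@H]1CC[C@H](Nc2c(C(=O)NC3CCCCC3)nc(Br)c3cccnc23)CC1` differs from compound 1 by cyclohexyl in place of 3-methoxybenzyl on an amide-type nitrogen, removing the chain carbon as well as the ring. Among the measured compounds shown here, no measured step tests that change, so the expected step of a 1.2-fold higher number from compound 1 to compound 4 (0.07 log units; within the scatter) is small, with no direction established. Compound 4 is estimated at 7000 nM, with a range from 2500 nM to 20000 nM.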

Compound 4, half-maximal inhibitory concentration: 4200 nM
The estimate for compound 4 lay 1.7-fold (0.22 log units) above the measured number, within the range that was stated.
By their numbers in this assay, from the lowest: compounds 4, 3, 1 and 2 (each within the scatter of the next, the first and the last beyond it).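

Putting cyclohexyl on the amide-type nitrogen removes the aromatic ring and the chain carbon together, yet in this assay the result stays close to both methoxybenzyl compounds: a 1.4-fold lower number from compound 1 to compound 4 (0.15 log units; within the scatter) and a 1.2-fold lower number from compound 3 to compound 4 (0.08 log units; within the scatter). Within the data shown here, only against the (furan-2-yl)methyl group does this change pass the scatter, with a 2.4-fold lower number from compound 2 to compound 4 (0.38 log units; beyond the scatter), the first modest step beyond it at this position. No measurement at hand explains these steps.

Still open, on these data alone, is whether an amine or a carboxylic acid on the cyclohexyl ring would shift the number. A longer chain between this nitrogen and the ring is equally untested here.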